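The source may report more compounds than this note shows. Statements on the series, on what has been measured and on what is new or still open speak of the compounds shown alone.

Compound 1, with the structure `O=C(Nc1ccc(Cl)c(-c2ccccn2)c1)c1cccnc1`, and compound 2, with the structure `O=C(Nc1ccc(Cl)c(-c2ccccn2)c1)c1ccncc1`, share one core and differ only in the ring attached to the carbonyl carbon. In an assay on C3H 10T1/2 cells for inhibition of Sonic hedgehog protein (Mus musculus), read by a luciferase reporter (a higher number here means a weaker inhibitor, a lower number a stronger inhibitor), compound 1 gives 600 nM, and in the same assay compound 2 gives 700 nM. The step of a 1.2-fold higher number from compound 1 to compound 2 (0.07 log units; within the scatter) lies within the scatter, so the two compounds are read as equal. Compound 2 thus has the higher of the two numbers, yet without a real gap to compound 1.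

Compound 3, with the structure `O=C(Nc1ccc(Cl)c(-c2ccccn2)c1)c1ccc(Cl)cc1`, is the next step from compound 2: 4-chlorophenyl in place of pyridin-4-yl on a carbonyl carbon. Among the measured compounds shown here, no measured step swaps a pyridyl for a phenyl ring here; the only step seen, a 1.2-fold higher number from compound 1 to compound 2 (0.07 log units; within the scatter), moves the nitrogen within a pyridyl and was within the scatter, so it carries little guidance. The expectation for compound 3 is therefore a step of about a 1.4-fold lower number from compound 2 to compound 3 (0.15 log units; within the scatter) in this assay, a value near 500 nM with a wide range from 150 nM to 2000 nM.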

Compound 3, half-maximal inhibitory concentration: 1500 nM
Compound 3: middle estimate off by 3.0-fold (0.48 log units), on the low side, and the stated range covers the measured number.
By their numbers in this assay, from the lowest: compounds 1 and 2 (each within the scatter of the next); then compound 3.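

In this assay the ring on the carbonyl carbon turns out not to be freely exchangeable: 4-chlorophenyl in place of pyridin-4-yl gives a 2.1-fold higher number from compound 2 to compound 3 (0.33 log units; beyond the scatter) and 4-chlorophenyl in place of pyridin-3-yl gives a 2.5-fold higher number from compound 1 to compound 3 (0.40 log units; beyond the scatter) as the second reading of the same change. Moving the nitrogen within the pyridyl ring made no real difference, whereas replacing the pyridyl ring with 4-chlorophenyl, a modest change in both steps, leaves compound 3 the weaker inhibitor of the three. Nothing measured here explains the rise in the number.

As far as these compounds go, this single change removes the ring nitrogen and adds a chlorine together, so it remains open which of the two carries the step. A plain phenyl ring on this carbonyl carbon would separate them, and a 4-aminophenyl or 4-methoxyphenyl group would show how other groups compare with chlorine there.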